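Ring-nitrogen substituent series: permeability working notes

A few compounds are considered here, and "the series" means these few. Any claim that something is new, unique, unknown or untested is made for them only; others in the source may bear on it.

Compound 2 `CCCC[C@H](NC(=O)[C@H](CCCCN)NC(=O)[C@H](CCCNC(=N)N)NC(=O)c1ccc(/C=C2\SC(=O)N(CCCC)C2=O)cc1)C(N)=O` is the starting point of this step. For the measured compounds named here, in an ADME assay for permeability, using PAMPA (a higher number here means that the compound crosses the layer faster, a lower number that the compound crosses the layer more slowly), compound 2 gives 1.18 10^-6 cm/s, the highest of the two numbers so far. Going by the values given here, its nearest neighbour is compound 1 `CCCC[C@H](NC(=O)[C@H](CCCCN)NC(=O)[C@H](CCCNC(=N)N)NC(=O)c1ccc(/C=C2\SC(=O)N(c3ccc(C)cc3)C2=O)cc1)C(N)=O`, which in this assay gives 0.66 10^-6 cm/s; the one measured step, a 1.8-fold higher number from compound 1 to compound 2 (0.25 log units; within the scatter), lies within the scatter, so the two compounds cannot be ordered. Compound 3 `CCCC[C@H](NC(=O)[C@H](CCCCN)NC(=O)[C@H](CCCNC(=N)N)NC(=O)c1ccc(/C=C2\SC(=O)N(CCOC(C)=O)C2=O)cc1)C(N)=O` is the next compound to be measured. The change from compound 2 to compound 3 is acetoxy in place of ethyl on a saturated chain carbon, two bonds along the chain from an amide-type nitrogen in a ring. Among the compounds with values here, only the step from compound 1 to compound 2 touches the same ring nitrogen, and it exchanged an aromatic group for a chain rather than altering a chain end, so it bears on the new change only loosely; no measured pair shows an acetoxy entering. Within what is known, substituent changes on this nitrogen have moved the numbers little. The step from compound 2 to compound 3 is therefore expected to stay within the scatter, a 1.3-fold lower number from compound 2 to compound 3 (0.12 log units; within the scatter), with no direction claimed. Compound 3 is estimated at 0.9 10^-6 cm/s, with a range from 0.4 10^-6 cm/s to 2 10^-6 cm/s.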

Compound 3, apparent permeability: "impermeable" (no number reported)
Compound 3: no number reported; the estimate stays without a comparison.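

In this assay, for the compounds shown here, compound 3 is reported only as impermeable, without a number, so no step from compound 2 to compound 3 can be read. No supporting data bear on this result. The compounds shown leave open how large the gap between compound 2 and compound 3 is, and what acetoxy in place of ethyl does at this chain position.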